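This account rests on a few compounds, and the source may have more. Where it says the series, first, only, none or still open, it means among the compounds named here.

Compound 1 `CCCC(=O)c1ccc(OCCCCOc2ccc(F)c(C(=O)O)c2)c(C)c1O` was tested in an assay on HEK293 cells for positive allosteric modulation of metabotropic glutamate receptor 2 (Rattus norvegicus), read by thallium flux, with a stated time of 2.5 min (a higher number here means that more compound is needed for the effect, a lower number that less compound is needed), where compound 1 gives 74 nM. Among the numbers shown this is the only one: a second compound, compound 2 `COC(=O)c1ccc(OCCCCOc2ccc(C(=O)CC3CCCC3)c(C)c2C)cc1`, also belongs to the set, but in this assay compound 2 gives "not determined" (no result reported), so no figure is available for comparison. Compound 1 therefore stands alone, with no measured neighbour to show how large a step a single change in the side chain can make.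

Compound 3 `Cc1c(OCCCCOc2ccc(F)c(C(=O)O)c2)ccc(C(=O)CC(C)(C)C)c1O` has not yet been measured. It is built from compound 1 by one change: tert-butyl in place of ethyl on a saturated chain carbon bound to a carbonyl carbon, which is tert-butyl in place of ethyl on a saturated chain carbon bound to a carbonyl carbon. Seen one bond further out, the propylcarbonyl of compound 1 becomes the neopentylcarbonyl of compound 3.

Among the compounds with values here, no pair of measured compounds shows what such a change does here, so the expectation rests on compound 1 alone. A modest step is expected, from compound 1 to compound 3 of about a 1.6-fold higher number from compound 1 to compound 3 (0.21 log units; within the scatter), not clearly beyond the usual scatter. For compound 3 the estimate in this assay is 120 nM, with a range from 40 nM to 400 nM.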

Compound 3, half-maximal effective concentration: 208 nM
Beside the measured number, compound 3's estimate is 1.7-fold (0.24 log units) below it, and the stated range covers the measured number.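

With tert-butyl in place of ethyl on a saturated chain carbon bound to a carbonyl carbon, this assay shows a 2.8-fold higher number from compound 1 to compound 3 (0.45 log units; beyond the scatter). Within the data shown here, this is the first measured step in the set, and it shows that this position is sensitive to the change: turning propylcarbonyl into neopentylcarbonyl means that more compound is needed for the effect, yet the effect can still be measured, so the position accepts tert-butyl without a complete loss of the read-out. Nothing shown here accounts for the direction or size of this step.

A single step cannot separate the effect of branching from that of simply adding carbon, so an isopropyl group or a longer straight chain such as n-butyl at the same place would be needed to tell the two apart. On these data alone, it also remains open how a group of a different kind, such as an amine or a hydroxyl on this chain, would change the number, and whether any replacement for ethyl would lower it rather than raise it.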